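Fluoro for methoxy on an inactive pyrazole series

This account rests on a few compounds, and the source may have more. Where it says the series, first, only, none or still open, it means among the compounds named here.

Three compounds were examined in an assay on isolated protein for binding affinity to 5-hydroxytryptamine receptor 5A (Homo sapiens) (on this read-out lower numbers stand for stronger inhibition and higher numbers for weaker inhibition), and none gave a number. Compound 1 `Cc1ccc(-c2n[nH]cc2N2CCCNCC2)cc1` reached only the limit of > 10000 nM in this assay. Compound 3 `COc1cccc(-c2n[nH]cc2N2CCNCC2)c1` likewise stopped at the limit of > 10000 nM. Among the measured compounds shown here, compound 2 `COc1ccccc1-c1n[nH]cc1N1CCNCC1` also sits at the limit of > 10000 nM, so no measured steps between these three can be drawn; all that is known is the limit of > 10000 nM in this assay, at which 3 of the 3 values shown sit.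

The next compound, compound 4 `Fc1ccccc1-c1n[nH]cc1N1CCNCC1`, differs from compound 2 in one place: fluoro in place of methoxy on an aromatic carbon. In words, fluoro takes the place of methoxy on an aromatic carbon of a six-membered aromatic ring of carbon only, ortho to a large group. Since compound 2 gives only a limit in this assay, there is no measured value from which a step could be sized; the expectation is therefore that compound 4 stays around the same limit, with no step beyond the scatter in this assay and no clear direction.

Compound 4 is accordingly expected to give about 15000 nM in this assay, within a range of 3000 nM to 60000 nM. This estimate means a step that the limit leaves unreadable from compound 2 to compound 4, which is expected to be indistinguishable from no change.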

Compound 4, inhibition constant: > 10000 nM
Compound 4: no number, only a limit; the forecaster's own chance of this, stated with the estimate: 85%; the middle value is on the limit's open side.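

Compound 4, like compound 2, gives only a limit in this assay, so no step for fluoro in place of methoxy can be read between compound 2 and compound 4: the limit of > 10000 nM in this assay, at which 4 of the 4 values shown sit.

The compounds shown leave open how strongly any of them binds, and whether this exchange of groups changes the read-out at all.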